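Replacing an Aryl Group with an Aryloxy Group

This account rests on a few compounds, and the source may have more. Where it says the series, first, only, none or still open, it means among the compounds named here.

Compound 1 `Fc1ccc(-c2ccc3c(NCCCNCc4ccco4)ccnc3c2)cc1` gives 9.47 in a physicochemical assay for acid dissociation.
Compound 2 `COc1cccc(CNCCCNc2ccnc3cc(-c4ccc(C(F)(F)F)cc4)ccc23)c1O` gives 9.47 in this assay.
Compound 3 `FC(F)(F)c1ccc(-c2ccc3c(NCCCNCc4ccco4)ccnc3c2)cc1` gives 9.47 in this assay.

All three measured values sit together, so compound 2 stands level with compound 1 and with compound 3 in this assay. The two measured steps bear this out: no change at the digits printed from compound 1 to compound 3 (within the scatter), and no change at the digits printed from compound 2 to compound 3 (within the scatter). One of those steps changed a group on an aromatic carbon, the other a group on a saturated chain carbon bound to an amine nitrogen, and neither moved the number beyond the scatter.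

Compound 4 `COc1cccc(CNCCCNc2ccnc3cc(Oc4ccc(C(C)(C)C)cc4)ccc23)c1O` differs from compound 2 in one place: 4-(tert-butyl)phenoxy in place of 4-(trifluoromethyl)phenyl on an aromatic carbon. This change, like the step from compound 1 to compound 3, sits on an aromatic carbon of the shared core, and that earlier step left the value unchanged. The step from compound 2 to compound 4 is therefore expected to stay within the scatter, at no change at the digits printed from compound 2 to compound 4 (within the scatter). Compound 4 is estimated to give 9.47 in this assay, with a range from 9.1 to 9.8.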

Compound 4, acid dissociation constant: 9.28
Compound 4: middle estimate off by 0.19 log units, on the high side, within the range that was stated.
By their numbers in this assay, from the lowest: compounds 4, 1, 2 and 3 (each within the scatter of the next).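

In this assay, 4-(tert-butyl)phenoxy in place of 4-(trifluoromethyl)phenyl on an aromatic carbon of the shared core gives a number 0.19 log units lower from compound 2 to compound 4 (within the scatter), so this exchange stays inside the scatter. The earlier step on an aromatic carbon exchanged only fluoro for trifluoromethyl, whereas here the whole group at this position is exchanged and the entering group brings an oxygen and a hydrogen-bond acceptor, and the read-out still holds. Nothing measured here explains this result.

A 4-(tert-butyl)phenyl group at this position would separate the oxygen link from the tert-butyl end, and these compounds leave open what each does alone. Also open, as far as these compounds go, is what an amine or a carboxylic acid on this aromatic carbon would give in this assay.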